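A few compounds are considered here, and "the series" means these few. Any claim that something is new, unique, unknown or untested is made for them only; others in the source may bear on it.

Measured compounds in the series:

Compound 1 `Cc1cc(Sc2ccccc2)c(S(C)(=O)=O)cc1C(=O)N=C(N)N`, in a functional assay for inhibition of sodium/hydrogen exchanger (Oryctolagus cuniculus) (on this read-out lower numbers stand for stronger inhibition and higher numbers for weaker inhibition), compound 1 gives 14 nM.
Compound 2 `Cc1cc(OCc2ccccc2)c(S(C)(=O)=O)cc1C(=O)N=C(N)N`, in this assay compound 2 gives 28 nM.
Compound 3 `Cc1cn(-c2cc(C)c(C(=O)N=C(N)N)cc2S(C)(=O)=O)cn1`, in this assay compound 3 gives 28 nM.

Compound 3 stands level with compound 2 at the digits shown, the two together being the highest numbers of the three. The step of no change at the digits printed from compound 2 to compound 3 (within the scatter) and the step of a 2.0-fold higher number from compound 1 to compound 3 (0.30 log units; within the scatter) both lie within the scatter, as does a 2.0-fold higher number from compound 1 to compound 2 (0.30 log units; within the scatter).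

Compound 4 `Cc1cc(-n2cccn2)c(S(C)(=O)=O)cc1C(=O)N=C(N)N` differs from compound 3 in one place: 1H-pyrazol-1-yl in place of 4-methyl-1H-imidazol-1-yl on an aromatic carbon.

All three measured steps concern exchange of the group on this same aromatic carbon, and each of them was small: a 2.0-fold higher number from compound 1 to compound 2 (0.30 log units; within the scatter), a 2.0-fold higher number from compound 1 to compound 3 (0.30 log units; within the scatter), no change at the digits printed from compound 2 to compound 3 (within the scatter). Those exchanges swapped groups of quite different kind, and none moved the number beyond the scatter. The exchange from compound 3 to compound 4 keeps a five-membered aromatic ring with 2 hetero atoms, 0 hydrogen-bond donors and 2 hydrogen-bond acceptors, and only drops a methyl, so in this assay no step beyond the scatter is expected, in either direction.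

Compound 4 is therefore expected at 28 nM, with a range from 12 nM to 65 nM. The step this estimate implies, no change at the digits printed from compound 3 to compound 4 (within the scatter), is expected to stay within the scatter.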

Compound 4, half-maximal inhibitory concentration: 25 nM
For compound 4 the middle estimate is 1.1-fold (0.05 log units) above the measured one; measured number inside the range.
By their numbers in this assay, from the lowest: compounds 1, 4, 2 and 3 (each within the scatter of the next).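

In this assay, within the data shown here, the exchange of 4-methyl-1H-imidazol-1-yl for 1H-pyrazol-1-yl gives a 1.1-fold lower number from compound 3 to compound 4 (0.05 log units; within the scatter) and is the only step between two five-membered aromatic rings with 2 hetero atoms, so on this aromatic carbon that exchange leaves the read-out within the scatter. Measured against the other two groups, 1H-pyrazol-1-yl gives a 1.1-fold lower number from compound 2 to compound 4 (0.05 log units; within the scatter) against benzyloxy and a 1.8-fold higher number from compound 1 to compound 4 (0.25 log units; within the scatter) against phenylsulfanyl, which places a fourth group on this carbon, ortho to a methylsulfonyl group, within the scatter of all three others and adds no step beyond it. Nothing available bears on why the read-out stays this flat across these groups.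

As far as these compounds go, all four groups at this position contain a ring, so it remains open whether an amine, a carboxylic acid or a longer alkyl chain on the same carbon would hold the read-out within the scatter as well. Every step shown also lies on this one carbon, leaving open what exchange of the methyl or the methylsulfonyl group on the shared core would do.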